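Moving the nitro group: from compound 3 to compound 4

This account rests on a few compounds, and the source may have more. Where it says the series, first, only, none or still open, it means among the compounds named here.

Of the compounds shown here, three sharing one core have been measured in a functional assay on PCO3 cells (Homo sapiens) for cytotoxicity, read by sulforhodamine B assay; on this read-out lower numbers stand for stronger inhibition of growth and higher numbers for weaker inhibition of growth. Compound 1 `CC1=CC[C@@H]([C@@](C)(O)CCCC(C)(C)NC(=S)N/N=C\c2ccc(O)cc2)CC1` gives 6230 nM. Compound 2 `CC1=CC[C@@H]([C@@](C)(O)CCCC(C)(C)NC(=S)N/N=C\c2ccc(N(C)C)cc2)CC1`, which carries a dimethylamino group on the ring in place of the hydroxy group, gives 13700 nM in this assay. Compound 3 `CC1=CC[C@@H]([C@@](C)(O)CCCC(C)(C)NC(=S)N/N=C\c2ccccc2[N+](=O)[O-])CC1`, with a 2-nitrophenyl group on the carbon with a double bond to nitrogen, gives 39900 nM in this assay and so stands highest of the three numbers, which here means the weakest inhibition of growth. The steps leading to it were a 6.4-fold higher number from compound 1 to compound 3 (0.81 log units; beyond the scatter) and a 2.9-fold higher number from compound 2 to compound 3 (0.46 log units; beyond the scatter); the remaining comparison is a 2.2-fold higher number from compound 1 to compound 2 (0.34 log units; beyond the scatter).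

Compound 4 `CC1=CC[C@@H]([C@@](C)(O)CCCC(C)(C)NC(=S)N/N=C\c2cccc([N+](=O)[O-])c2)CC1` has not yet been measured. It differs from compound 3 in one place: 3-nitrophenyl in place of 2-nitrophenyl on a carbon with a double bond to nitrogen. Among the measured compounds shown here, none of the measured steps moves a group from one place on this ring to another; they only show that changing the group on the ring shifts the read-out by modest amounts, and that the nitro-bearing ring gave the highest number. A change of position alone is therefore expected to matter modestly at most, with the direction uncertain but leaning toward a somewhat lower number than compound 3. The step from compound 3 to compound 4 is expected to be a 1.6-fold lower number from compound 3 to compound 4 (0.20 log units; within the scatter). Compound 4 is expected to give about 25000 nM in this assay, within a range from 8000 nM to 80000 nM.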

Compound 4, concentration for 50% growth inhibition: 5600 nM
Compound 4: the middle estimate sits 4.5-fold (0.65 log units) above what was measured; measured number outside the range, below it.
By their numbers in this assay, from the lowest: compounds 4 and 1 (each within the scatter of the next); then compound 2; then compound 3.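

In this assay, moving the nitro group from 2-nitrophenyl to 3-nitrophenyl gives a 7.1-fold lower number from compound 3 to compound 4 (0.85 log units; beyond the scatter) even though the two compounds have the same atoms, so the place of a group on this ring can matter as much as any change of group seen so far. The high number of compound 3 therefore does not belong to the nitro group as such: there is a 2.4-fold lower number from compound 2 to compound 4 (0.39 log units; beyond the scatter) and also a 1.1-fold lower number from compound 1 to compound 4 (0.05 log units; within the scatter), which leaves compound 4 and compound 1 indistinguishable in this assay, although they carry different groups in different places. Nothing available here explains why this shift in place has so large an effect.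

Among the compounds shown here, the hydroxy and dimethylamino groups each appear in only one place on the ring in these compounds, so it remains open whether moving either of them would change the number as much as moving the nitro group did. On these data alone, it is also open whether a nitrile or a carboxylic acid, put in the place the nitro group holds in 3-nitrophenyl, would give a number like that of compound 4 or a quite different one.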